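A Third Methoxy Group Enters on the Ketone Side

The source may report more compounds than this note shows. Statements on the series, on what has been measured and on what is new or still open speak of the compounds shown alone.

Compound 1 `COc1ccc(-c2cc(/C=C/C(=O)c3cc(OC)c(OC)c(OC)c3)[nH]n2)cc1OC` and compound 2 `COc1ccc(C(=O)/C=C/c2cc(-c3cc(OC)c(OC)c(OC)c3)n[nH]2)cc1OC` share one core, arranged in two different ways. In a functional assay on UO-31 cells (Homo sapiens) for inhibition, read by sulforhodamine B assay, with a stated time of 48 h (a lower number here means a stronger inhibitor of growth, a higher number a weaker inhibitor of growth), compound 1 gives 1270 nM, and compound 2 gives 1280 nM; the two numbers lie within the usual scatter of each other, so neither can be set apart. Compound 3 `COc1cc(C(=O)/C=C/c2cc(-c3cc(OC)c(OC)c(OC)c3)n[nH]2)cc(OC)c1OC` differs from compound 2 by methoxy in place of hydrogen on an aromatic carbon. Within the data shown here, no measured pair shows what this change does here, so only a modest step is expected. Compound 3 is expected to give 900 nM, with a range from 300 nM to 2700 nM. The expected step of a 1.4-fold lower number from compound 2 to compound 3 (0.15 log units; within the scatter) stays close to the scatter.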

Compound 3, concentration for 50% growth inhibition: 1190 nM
Estimate against measurement, compound 3: 1.3-fold (0.12 log units) below; low and high end bracket the measured number.
By their numbers in this assay, from the lowest: compounds 3, 1 and 2 (each within the scatter of the next).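

Methoxy in place of hydrogen on this aromatic carbon, ortho to a methoxy group, produces no readable change in this assay: the numbers show a 1.1-fold lower number from compound 2 to compound 3 (0.03 log units; within the scatter) and also a 1.1-fold lower number from compound 1 to compound 3 (0.03 log units; within the scatter). This position therefore holds the added methoxy group without any shift in growth inhibition beyond the scatter. Nothing measured here offers an explanation for this flat result.

Still open, from the compounds shown here alone, is whether a hydroxyl group, an amine or a longer chain on this carbon would move the number. Also open, going by these compounds, is what the same methoxy group would do in the arrangement of compound 1.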